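The source may report more compounds than this note shows. Statements on the series, on what has been measured and on what is new or still open speak of the compounds shown alone.

Measured so far in a functional assay on SiHa cells (Homo sapiens) for antiproliferative activity, read by CCK-8 assay, with a stated time of 72 h; a higher number here means a weaker inhibitor, a lower number a stronger inhibitor:
- compound 1 `COc1ccc(-c2cncnc2-c2cc(OC)c(OC)c(OC)c2)cc1O`: 2750 nM
- compound 2 `COc1cc(-c2ncncc2-c2ccc(SC)cc2)cc(OC)c1OC`: 560 nM
- compound 3 `COc1ccc(-c2cncnc2-c2cc(OC)c(OC)c(OC)c2)nc1`: 1750 nM

All three share one core and differ only in the group on an aromatic carbon of the six-membered aromatic ring with 2 nitrogen. The record shows a 1.6-fold lower number from compound 1 to compound 3 (0.20 log units; within the scatter), so those two values cannot be told apart. It also shows a 3.1-fold higher number from compound 2 to compound 3 (0.49 log units; beyond the scatter), which places compound 3 clearly on the weaker side of compound 2.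

Next is compound 4 `COc1cc(-c2ncncc2-c2ccc3cc[nH]c3c2)cc(OC)c1OC`, with the change (1H-indol-6-yl in place of 5-methoxypyridin-2-yl on an aromatic carbon). Going by the values given here, no measured compound carries 1H-indol-6-yl, so only the swaps at this same place bear on it. These are modest: a 4.9-fold lower number from compound 1 to compound 2 (0.69 log units; beyond the scatter), alongside the step from compound 2 to compound 3 already given. The entering group has a six-membered aromatic ring of carbon only, as does the 4-(methylsulfanyl)phenyl of compound 2 at 560 nM. Compound 1 at 2750 nM has such a ring too and goes against any simple pattern, so the expectation is tentative.

A modest drop is expected, of about the size already seen at this place: a 4.4-fold lower number from compound 3 to compound 4 (0.64 log units; beyond the scatter). For compound 4 the estimated value in this assay is 400 nM, with an expected range of 80 nM to 1600 nM.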

Compound 4, half-maximal inhibitory concentration: 2180 nM
The estimate for compound 4 lay 5.5-fold (0.74 log units) below the measured number; the measured number lies above the stated range.
By their numbers in this assay, from the lowest: compound 2; then compounds 3, 4 and 1 (each within the scatter of the next).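

In this assay, the fused 1H-indol-6-yl, with its five-membered aromatic ring and hydrogen-bond donor, cannot be told apart from 5-methoxypyridin-2-yl (a 1.2-fold higher number from compound 3 to compound 4 (0.10 log units; within the scatter)) or from 3-hydroxy-4-methoxyphenyl (a 1.3-fold lower number from compound 1 to compound 4 (0.10 log units; within the scatter)). A six-membered aromatic ring of carbon only in the entering group is therefore not enough to reach the level of compound 2, since compound 1 and compound 4 both carry such a ring and stay in the same band as compound 3. At this place the 4-(methylsulfanyl)phenyl group alone stands apart, with its steps to all three others beyond the scatter, including a 3.9-fold higher number from compound 2 to compound 4 (0.59 log units; beyond the scatter), and nothing measured on these compounds accounts for that separation.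

As far as these compounds go, whether the sulfur-bearing group itself sets compound 2 apart remains open, and a close series of 4-methoxyphenyl, 4-(methylsulfonyl)phenyl and 4-aminophenyl groups at the same carbon would test this. It is also unsettled whether the indole result is specific to attachment through its 6-position, which 1H-indol-5-yl or 1-methylindol-6-yl would address.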